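The source may report more compounds than this note shows. Statements on the series, on what has been measured and on what is new or still open speak of the compounds shown alone.

Measured in a functional assay on SW480 cells (Homo sapiens) for antiproliferative activity, read by MTT assay, with a stated time of 48 h; on this read-out higher numbers stand for weaker inhibition and lower numbers for stronger inhibition:
- Compound 1 (`CCCCCC(CCO)n1cnc2c(NC)ncnc21`): > 50000 nM, a limit
- Compound 2 (`CCCCCC(CCO)n1cnc2c(N)ncnc21`): > 50000 nM, a limit
- Compound 3 (`CCCCCC(CCO)n1cnc2cncnc21`): > 50000 nM, a limit

Compound 1 has no number, only (the limit of > 50000 nM in this assay, at which 3 of the 3 values shown sit). Compound 4 (`CCCCCCCCC(CCO)n1cnc2c(NC)ncnc21`) differs from it as follows: propyl in place of hydrogen on a saturated chain carbon, six bonds along the chain from an aromatic nitrogen. The measured steps, a step that the two limits leave unreadable from compound 1 to compound 2, a step that the two limits leave unreadable from compound 1 to compound 3 and a step that the two limits leave unreadable from compound 2 to compound 3, all change the substituent on the shared core and leave the chain alone. None of them gives a size for lengthening the chain, so the expectation in this assay is weak: little or no change, with any move toward stronger inhibition. The expected step is an at least 1.2-fold lower number from compound 1 to compound 4 (0.09 log units; that floor lies within the scatter). For compound 4 the estimated value is 40000 nM, with an expected range of 12000 nM to 100000 nM.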

Compound 4, half-maximal inhibitory concentration: 3770 nM
The estimate for compound 4 lay 11-fold (1.03 log units) above the measured number; the measured number lies below the stated range.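

In this assay, among these compounds, propyl in place of hydrogen on a saturated chain carbon, six bonds along the chain from an aromatic nitrogen, gives an at least 13-fold lower number from compound 1 to compound 4 (1.12 log units; beyond the scatter), the only readable step here. The steps among compound 1, compound 2 and compound 3 cannot be read, and only the chain change gives a number: the limit of > 50000 nM in this assay, at which 3 of the 4 values shown sit. This chain position therefore affects the read-out in a way the substituent changes could not show, though the size remains a floor.

From the compounds shown here alone, whether a longer chain would go further remains open. Also open, going by these compounds, are what an amine on the chain would do and whether amino in place of methylamino matters on the lengthened chain.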